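Adding a methyl to the chain carbon of compound 3

The source may report more compounds than this note shows. Statements on the series, on what has been measured and on what is new or still open speak of the compounds shown alone.

Compound 1 `CC(C)CNC(=O)c1[nH]cnc1C(=O)Nc1ccc(Cl)c(Cl)c1` gives 7200 nM in a functional assay on HL-60 cells (Homo sapiens), with a stated time of 4 days; on this read-out higher numbers stand for weaker inhibition and lower numbers for stronger inhibition.
Compound 2 `C[C@@H](NC(=O)c1[nH]cnc1C(=O)Nc1ccc(Cl)c(Cl)c1)c1ccccc1` gives 5900 nM in this assay.
Compound 3 `CC(C)(C)OC(=O)CNC(=O)c1[nH]cnc1C(=O)Nc1ccc(Cl)c(Cl)c1` gives 25400 nM in this assay.

Compound 3 stands with the highest number of the three: the step of a 3.5-fold higher number from compound 1 to compound 3 (0.55 log units; beyond the scatter) and the step of a 4.3-fold higher number from compound 2 to compound 3 (0.63 log units; beyond the scatter) both lie beyond the scatter, so it is the weakest inhibitor of the measured set. Compound 4 `C[C@@H](NC(=O)c1[nH]cnc1C(=O)Nc1ccc(Cl)c(Cl)c1)C(=O)OC(C)(C)C` differs from compound 3 in one place: methyl in place of hydrogen on a saturated chain carbon bound to an amide-type nitrogen and a carbonyl carbon. Among the compounds with values here, no measured step adds a single carbon to such a chain carbon. The step of a 1.2-fold lower number from compound 1 to compound 2 (0.09 log units; within the scatter) exchanges one whole substituent for another and stays within the scatter; the two steps that reach compound 3 exchange the whole substituent as well. Within the data shown here, nothing among the measured pairs therefore speaks to this small change, and no step beyond the scatter is expected in this assay. Compound 4 is estimated at 20000 nM, with a range from 8000 nM to 50000 nM, which means an expected step of a 1.3-fold lower number from compound 3 to compound 4 (0.10 log units; within the scatter).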

Compound 4, half-maximal inhibitory concentration: 2500 nM
Compound 4: the middle estimate sits 8.0-fold (0.90 log units) above what was measured; the measured number lies below the stated range.
By their numbers in this assay, from the lowest: compound 4; then compounds 2 and 1 (each within the scatter of the next); then compound 3.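

In this assay a methyl in place of hydrogen on the saturated chain carbon bound to an amide-type nitrogen and a carbonyl carbon gives a 10-fold lower number from compound 3 to compound 4 (1.01 log units; beyond the scatter) and is the largest step among these compounds, so this position responds strongly to a very small addition, which the earlier exchanges of whole substituents could not show. With a 2.4-fold lower number from compound 2 to compound 4 (0.37 log units; beyond the scatter) and a 2.9-fold lower number from compound 1 to compound 4 (0.46 log units; beyond the scatter) as its other two steps, compound 4 becomes the strongest inhibitor of the four, and a tert-butoxycarbonyl-bearing side chain therefore does not by itself go with the weakest number, as compound 3 alone had suggested. Nothing shown here accounts for the size of this step.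

The compounds shown leave open whether the gain is specific to methyl or would persist with a longer chain such as ethyl at this carbon, and what the opposite configuration at this carbon would give. They also leave open whether the tert-butyl ester is needed for this result, which a free carboxylic acid or a primary amide in its place would test on the 1-(tert-butoxycarbonyl)ethyl side chain.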